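This account rests on a few compounds, and the source may have more. Where it says the series, first, only, none or still open, it means among the compounds named here.

Measured so far in an assay on isolated protein for inhibition of aldehyde dehydrogenase 1A1 (Homo sapiens); a higher number here means a weaker inhibitor, a lower number a stronger inhibitor:
compound 1 `Cn1ncc2c(=O)n(-c3ccccc3)c(/C=C/c3cccc(F)c3)nc21` gives 270 nM
compound 2 `Cn1ncc2c(=O)n(-c3ccccc3)c(SC(C)(C)c3ccccc3)nc21` gives 1900 nM
compound 3 `CC(Sc1nc2nn(C3(C)COC3)cc2c(=O)n1-c1ccccc1)c1ccccc1` gives 93 nM

Compound 2 stands at the highest number of the three, beyond the scatter from both compound 1 and compound 3. Compound 4 `CCC(Sc1nc2c(cnn2C)c(=O)n1-c1ccccc1)c1ccccc1` is not yet measured. It keeps the core of compound 2 and is rearranged only at the sulfur: 1-phenylpropyl in place of 1-methyl-1-phenylethyl on a sulfur. Among the measured compounds shown here, no directly comparable pair has been measured. Around the sulfur, the closest in shape to compound 4 is compound 3, which gives 93 nM, but it differs from compound 2 at another place as well, so its number is only a loose guide. A drop in this assay beyond the scatter is nonetheless expected; the step from compound 2 to compound 4 is estimated at a 5.4-fold lower number from compound 2 to compound 4 (0.73 log units; beyond the scatter), giving compound 4 an expected 350 nM, within 80 nM to 1500 nM.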

Compound 4, half-maximal inhibitory concentration: 150 nM
For compound 4 the middle estimate is 2.3-fold (0.37 log units) above the measured one; measured number inside the range.
By their numbers in this assay, from the lowest: compounds 3, 4 and 1 (each within the scatter of the next, the first and the last beyond it); then compound 2.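

In this assay, rearranging the same 9 carbons on a sulfur, 1-phenylpropyl in place of 1-methyl-1-phenylethyl, gives a 13-fold lower number from compound 2 to compound 4 (1.10 log units; beyond the scatter), a large step with the core unchanged. This position therefore responds to how the carbons of the group are joined, not only to which atoms it holds. Nothing measured accounts for this step. Still open, on these data alone, is whether a longer chain such as 1-phenylbutyl keeps this level, and how an amine or a carboxylic acid on that chain would read.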